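Carbamate Aryl Swap: Methoxy to Fluoro on Compound 3

The source may hold more compounds than are shown below. What is called first, only, known or untested is meant among the compounds shown, and "the series" means these compounds.

Measured so far in a functional assay on PANC-1 cells (Homo sapiens) for inhibition, read by MTT assay, with a stated time of 24 h, tested at 10 uM; a higher number here means more inhibition at the concentration tested (going by the name of the read-out), a lower number less inhibition:
- compound 1 `CC(C)=CCC/C(C)=C/CC1Cc2c(OCCCNC(=O)c3cccs3)cc(=O)n(CCCO)c2CC1(C)C` gives 72.8%
- compound 2 `COc1ccc(OCCCOc2cc(=O)n(CCCO)c3c2CC(C/C=C(\C)CCC=C(C)C)C(C)(C)C3)cc1` gives 20%
- compound 3 `COc1cccc(NC(=O)Oc2cc(=O)n(CCCO)c3c2CC(C/C=C(\C)CCC=C(C)C)C(C)(C)C3)c1` gives 47%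

Compound 3 stands second highest of the three. It sits apart from compound 1 by a number 25.8 percentage points lower from compound 1 to compound 3 (beyond the scatter) and apart from compound 2 by a number 27 percentage points higher from compound 2 to compound 3 (beyond the scatter), both beyond the scatter, so its position in the middle is secure on these numbers.

Compound 4 `CC(C)=CCC/C(C)=C/CC1Cc2c(OC(=O)Nc3cccc(F)c3)cc(=O)n(CCCO)c2CC1(C)C` differs from compound 3 in one place only: fluoro in place of methoxy on an aromatic carbon. The ring carrying the change is the six-membered aromatic ring of carbon only at the end of the (3-methoxyphenyl)carbamoyl group, which becomes (3-fluorophenyl)carbamoyl.

Among the measured compounds shown here, none of the measured steps touches that ring. The large step of a number 52.8 percentage points lower from compound 1 to compound 2 (beyond the scatter) and the modest steps of a number 25.8 percentage points lower from compound 1 to compound 3 (beyond the scatter) and a number 27 percentage points higher from compound 2 to compound 3 (beyond the scatter) all replace the whole side chain on the oxygen of the core, not a single substituent on a distal aryl ring. They therefore set no direction for the present change, and the step of no change at the digits printed from compound 3 to compound 4 (within the scatter) is expected to fall within the scatter, with a small chance of a modest move either way. Compound 4 is accordingly estimated at 47%, with a range from 30% to 63%.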

Compound 4, a percentage reported as inhibition, at one concentration (the size of the read-out at that concentration, not a potency): 52.3%
Beside the measured number, compound 4's estimate is 5.3 percentage points below it; measured number inside the range.
By their numbers in this assay, from the lowest: compound 2; then compounds 3 and 4 (each within the scatter of the next); then compound 1.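

In this assay, among the compounds shown here, the exchange of methoxy for fluoro on this aromatic carbon gives a number 5.3 percentage points higher from compound 3 to compound 4 (within the scatter), the first reading at this place on the ring, and it shows that swapping a group of two heavy atoms and one hydrogen-bond acceptor for a single fluorine atom with no acceptor leaves the inhibition within the scatter. The standing of the carbamoyl side chain also holds with either ring substituent, since the change from 3-(4-methoxyphenoxy)propyl to (3-fluorophenyl)carbamoyl on the oxygen of the core gives a number 32.3 percentage points higher from compound 2 to compound 4 (beyond the scatter) and the change from 3-(((thiophen-2-yl)carbonyl)amino)propyl gives a number 20.5 percentage points lower from compound 1 to compound 4 (beyond the scatter), in the same directions as the matching steps from the methoxy compound. Nothing available here accounts for how this ring position responds to the exchange.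

Going by these compounds, whether a plain hydrogen, an amine or a carboxylic acid on this same carbon would move the reading beyond the scatter remains open. So does the effect of a fluoro on another carbon of this ring, and a reading at a single concentration cannot tell whether compound 3 and compound 4 would differ in potency.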